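From Methoxymethyl to Fluoro: Expected Agonist Potency

A few compounds are considered here, and "the series" means these few. Any claim that something is new, unique, unknown or untested is made for them only; others in the source may bear on it.

Compound 1 `COCc1ccccc1C1Cc2nccn2C1` carries a methoxymethyl group on its phenyl ring. In a functional assay on CHO cells for agonist activity at Alpha-1B adrenergic receptor (Homo sapiens), read by FLIPR and calcium flux (on this read-out higher numbers stand for an effect only at larger amounts of compound and lower numbers for an effect already at smaller amounts), compound 1 gives > 10000 nM, which is a limit of the measurement and not a number. A second measured compound, compound 2 `COc1cccc(C2CCc3nc[nH]c3C2)c1`, rests on a different core. In this assay compound 2 gives > 10000 nM, again a limit and not a number. Within the data shown here, compound 1 thus stands at the limit of > 10000 nM in this assay, at which 2 of the 2 values shown sit, the edge of what the measurement can report, and no step between measured compounds is available to build on. Compound 3 `Fc1ccccc1C1Cc2nccn2C1` has not yet been measured. It differs from compound 1 by fluoro in place of methoxymethyl on an aromatic carbon. Without a measured step for guidance, the change is expected to bring a modest shift in this assay, more likely toward an effect at smaller amounts than away from it. The estimated change is an at least 2.0-fold lower number from compound 1 to compound 3 (0.30 log units; that floor lies within the scatter). For compound 3 the expected value in this assay is 5000 nM, within a range from 300 nM to 30000 nM.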

Compound 3, half-maximal effective concentration: 1770 nM
Compound 3: middle estimate off by 2.8-fold (0.45 log units), on the high side; the measured number falls inside the stated range.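

Compound 3 shows that, on this core, a change at this one aromatic carbon is enough to turn a limit into a real number in this assay on this read-out. Fluoro in place of methoxymethyl gives an at least 5.6-fold lower number from compound 1 to compound 3 (0.75 log units; beyond the scatter) and so marks this position as one that matters for agonist activity at this receptor. That step has no upper end and the true gap could be larger, because compound 1 has only a limit and not a number: the limit of > 10000 nM in this assay, at which 2 of the 3 values shown sit.

A single pair cannot tell whether fluoro itself or simply the loss of methoxymethyl accounts for the shift. The compounds shown also leave open how a chloro group, a nitrile or an amine on this same aromatic carbon would read out.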